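A few compounds are considered here, and "the series" means these few. Any claim that something is new, unique, unknown or untested is made for them only; others in the source may bear on it.

Compound 3 `COc1ccc(-c2cn(-c3cccc(C(=O)/C=C/c4ccc(O)c(OC)c4)c3)c(=O)[nH]2)cc1` gives 2630 nM in a functional assay on SK-MEL-5 cells (Homo sapiens) for inhibition (a lower number here means a stronger inhibitor of growth, a higher number a weaker inhibitor of growth), and so stands highest of the three numbers, though within the scatter of both neighbours. Compound 1 `COc1cc(/C=C/C(=O)c2cccc(-n3cc(-c4ccccc4)[nH]c3=O)c2)ccc1O` gives 1590 nM in this assay, and compound 2 `O=C(/C=C/c1cccc(O)c1)c1cccc(-n2cc(-c3ccc(Cl)cc3)[nH]c2=O)c1` gives 1530 nM. Among the compounds with values here, the one measured step, a 1.7-fold higher number from compound 1 to compound 3 (0.22 log units; within the scatter), stayed within the scatter. Compound 4 `COc1cc(/C=C/C(=O)c2cccc(-n3cc(-c4ccc(Cl)cc4)[nH]c3=O)c2)ccc1O` differs from compound 3 by chloro in place of methoxy on an aromatic carbon. Compound 2 already carries the chloro group, though on a different partner, and its number sits close to those of compound 1 and compound 3, so no step beyond the scatter is expected here; the estimated step of a 1.5-fold lower number from compound 3 to compound 4 (0.19 log units; within the scatter) is small. Compound 4 is therefore expected to give about 1700 nM in this assay, between 700 nM and 4000 nM.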

Compound 4, concentration for 50% growth inhibition: 1800 nM
Beside the measured number, compound 4's estimate is 1.1-fold (0.02 log units) below it, within the range that was stated.
By their numbers in this assay, from the lowest: compounds 2, 1, 4 and 3 (each within the scatter of the next).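

Chloro in place of methoxy on this aromatic carbon, para to a large group, gives (a 1.5-fold lower number from compound 3 to compound 4 (0.16 log units; within the scatter)), and chloro in place of hydrogen there gives (a 1.1-fold higher number from compound 1 to compound 4 (0.05 log units; within the scatter)), so hydrogen, methoxy and chloro all lie within the scatter in this assay. With chloro present, 4-hydroxy-3-methoxyphenyl in place of 3-hydroxyphenyl also stays within the scatter (a 1.2-fold higher number from compound 2 to compound 4 (0.07 log units; within the scatter)). Nothing here gives a reason for these small steps. The compounds shown leave open whether an amine or a carboxylic acid on this aromatic carbon would move the number beyond the scatter.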